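Same halogen swap, from one core to another

A few compounds are considered here, and "the series" means these few. Any claim that something is new, unique, unknown or untested is made for them only; others in the source may bear on it.

Compound 1 `C=C1C[C@]23C[C@@]1(O)CC[C@H]2c1ccc(OS(=O)(=O)c2ccc(C)cc2)c(C)c1[C@@H]3Cn1cc(-c2ccc(Cl)cc2)nn1` in a functional assay on MCF7 cells (Homo sapiens) for cytotoxicity, read by MTT assay, with a stated time of 4 days (on this read-out lower numbers stand for stronger inhibition and higher numbers for weaker inhibition), gives > 20000 nM, a limit of the assay.
Compound 2 `C=C1C[C@]23C[C@@]1(O)CC[C@H]2c1ccc(OS(=O)(=O)c2ccc(C)cc2)c(C)c1[C@@H]3Cn1cc(-c2ccc(Br)cc2)nn1` in this assay gives > 20000 nM, also a limit.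
Compound 3 `C=C1C[C@]23C[C@@]1(O)CC[C@@H]2c1cccc(C)c1[C@@H]3Cn1cc(-c2ccc(Cl)cc2)nn1` in this assay gives > 20000 nM, again a limit.

Compound 1 and compound 2 share one core and differ in a single place: bromo in place of chloro on an aromatic carbon. Within the data shown here, since both values sit at a limit, the step that the two limits leave unreadable from compound 1 to compound 2 cannot be read; its size is not known, only that neither compound reached a measurable number. That all three values rest at the same point is captured by the limit of > 20000 nM in this assay, at which 3 of the 3 values shown sit.

Compound 3 carries a different core; the difference between the core of compound 3 and the core of compound 1 is not broken down here. Compound 4 `C=C1C[C@]23C[C@@]1(O)CC[C@@H]2c1cccc(C)c1[C@@H]3Cn1cc(-c2ccc(Br)cc2)nn1` has not yet been measured in this assay. It stands to compound 3 as compound 2 stands to compound 1: bromo in place of chloro on an aromatic carbon. The place of the change is the same in both pairs, word for word, so this is the same change made on a second core.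

For compound 4 the expectation rests on compound 3, whose value > 20000 nM is a limit, and on the first pair, where the same change left compound 2 at a limit too. Compound 4 is therefore expected to remain at or near the limit, with an estimated step that the limit leaves unreadable from compound 3 to compound 4. The estimate for compound 4 is 30000 nM, spanning 12000 nM to 80000 nM.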

Compound 4, half-maximal inhibitory concentration: > 20000 nM
Compound 4: a limit, no number; the forecaster's own chance of this, stated with the estimate: 85%; the middle value is on the limit's open side.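

Compound 4 gives > 20000 nM in this assay, a limit and not a number. Compound 3 rests at a limit too, so no step can be read for the swap from chloro to bromo between compound 3 and compound 4. The series stays at one point: the limit of > 20000 nM in this assay, at which 4 of the 4 values shown sit. The compounds shown leave open how strongly any of them acts on these cells, and whether the halogen matters at all.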